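Phenyl for isopropyl on the ring double bond

A few compounds are considered here, and "the series" means these few. Any claim that something is new, unique, unknown or untested is made for them only; others in the source may bear on it.

Of the compounds shown here, two of the shared core have been measured in an assay on isolated protein for binding affinity to ecdysone receptor (Lucilia cuprina), read by fluorescence polarization, with a stated time of 3 h; a higher number here means a weaker inhibitor, a lower number a stronger inhibitor. Compound 1 `C=C1C(C)=C(C#N)C(=O)N1c1ccccc1C(F)(F)F` gives 48000 nM in this assay. Compound 2 `C=C1C(C(C)C)=C(C#N)C(=O)N1c1c(C)cccc1C(C)C` gives 47000 nM in this assay, the lower of the two numbers, though the gap to compound 1 lies within the scatter, so no order between them can be read. For the measured compounds named here, both numbers sit at the weak end of what this assay reports, and no step between measured compounds differing in one place is available to calibrate the next change.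

Compound 3 `C=C1C(c2ccccc2)=C(C#N)C(=O)N1c1c(C)cccc1C(C)C` is the next member. It differs from compound 2 by phenyl in place of isopropyl on a double-bonded ring carbon. Going by the values given here, nothing among the measured compounds shows what a change at this position does in this assay, so the direction of the step is open. Compound 3 is expected to stay in the same weak region as compound 2, with an estimated step of a 1.2-fold lower number from compound 2 to compound 3 (0.07 log units; within the scatter) in this assay, small enough that it may fall within the scatter. The estimate for compound 3 in this assay is 40000 nM, with a range from 10000 nM to 150000 nM.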

Compound 3, half-maximal inhibitory concentration: 55000 nM
The estimate for compound 3 lay 1.4-fold (0.14 log units) below the measured number; the measured number falls inside the stated range.
By their numbers in this assay, from the lowest: compounds 2, 1 and 3 (each within the scatter of the next).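

In this assay, for the compounds shown here, the first step at this position is a 1.2-fold higher number from compound 2 to compound 3 (0.07 log units; within the scatter), for phenyl in place of isopropyl on a double-bonded ring carbon. The swap takes the group from 3 to 6 heavy atoms and adds a six-membered aromatic ring of carbon only, yet compound 2 and compound 3 stay within the scatter of each other, so the step has no readable direction and this change separates the two compounds by nothing the assay can resolve. No measurement at hand offers an explanation for this result.

Isopropyl and phenyl both count 0 hydrogen-bond donors, 0 hydrogen-bond acceptors and no net charge, so it remains open whether an amine, a carboxylic acid or a longer chain on this ring carbon would give a number beyond the scatter of compound 2. Going by these compounds alone, the contribution of the group on the ring nitrogen also remains open, as compound 1 differs from compound 2 in more than one place and offers no clean step.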